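Ester variation on the shared core: formate to acetate

The source may report more compounds than this note shows. Statements on the series, on what has been measured and on what is new or still open speak of the compounds shown alone.

Measured so far in a functional assay on NFS-60 cells (Mus musculus) for inhibition, read by MTT assay, with a stated time of 72 h; a lower number here means a stronger inhibitor, a higher number a weaker inhibitor:
Compound 1 `O=C(OC1(C(=O)Nc2ccc([N+](=O)[O-])cc2)CCCCC1)c1ccc(Br)cc1` gives 236 nM.
Compound 2 `O=COC1(C(=O)Nc2ccc([N+](=O)[O-])cc2)CCCCC1` gives 33.8 nM.

Compound 2 stands at the lowest of the two numbers in this assay; its nearest neighbour is compound 1, and the step of a 7.0-fold lower number from compound 1 to compound 2 (0.84 log units; beyond the scatter) separates them, beyond the scatter. Compound 3 `CC(=O)OC1(C(=O)Nc2ccc([N+](=O)[O-])cc2)CCCCC1` is the next member, differing from compound 2 by methyl in place of hydrogen on a carbonyl carbon.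

Among the compounds with values here, the one measured step that bears on this place is a 7.0-fold lower number from compound 1 to compound 2 (0.84 log units; beyond the scatter): it changed the same carbonyl carbon, but exchanged a far larger group for hydrogen. The move from hydrogen to methyl is much smaller, so that step sets only a rough upper bound for the size to expect. For compound 3 in this assay a step of a 1.5-fold higher number from compound 2 to compound 3 (0.17 log units; within the scatter) is expected, most likely within the scatter or a slight rise, and compound 3 is estimated at 50 nM, with a range from 20 nM to 130 nM.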

Compound 3, half-maximal inhibitory concentration: 517 nM
Compound 3: middle estimate off by 10-fold (1.01 log units), on the low side; measured number above the stated range.
By their numbers in this assay, from the lowest: compound 2; then compound 1; then compound 3.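

In this assay this carbonyl carbon responds sharply even to the smallest addition: methyl in place of hydrogen gives a 15-fold higher number from compound 2 to compound 3 (1.18 log units; beyond the scatter) and so moves the number further than the exchange of 4-bromophenyl for hydrogen did. The numbers also do not follow the size of the group, since methyl in place of 4-bromophenyl gives a 2.2-fold higher number from compound 1 to compound 3 (0.34 log units; beyond the scatter) and compound 3, with the smaller group, therefore goes against any steady rise from hydrogen through methyl to 4-bromophenyl. No measurement here accounts for this order.

Going by these compounds, whether a longer chain such as ethyl or propyl would stay near compound 3 or fall back toward compound 1 remains open. Also open is how an unsubstituted phenyl or an amine on this carbonyl carbon would compare with the three groups shown.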